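Benzylamino series: from compound 3 to compound 4

The source may hold more compounds than are shown below. What is called first, only, known or untested is meant among the compounds shown, and "the series" means these compounds.

Of the compounds shown here, three on one shared core have been read in a functional assay on K562 cells (Homo sapiens) for inhibition, with a stated time of 72 h; a lower number here means a stronger inhibitor, a higher number a weaker inhibitor. Compound 1 (`NC1CCC(Nc2nc(NCc3ccc(-c4ccccc4)cc3)c3ncn(C4CCCC4)c3n2)CC1`) gives 530 nM, compound 2 (`NC1CCC(Nc2nc(NCc3ccc(-c4ccsc4)nc3)c3ncn(C4CCCC4)c3n2)CC1`) gives 150 nM and compound 3 (`NC1CCC(Nc2nc(NCc3cc(Cl)ccc3O)c3ncn(C4CCCC4)c3n2)CC1`) gives 690 nM. Compound 3 stands level with one neighbour, at a 1.3-fold higher number from compound 1 to compound 3 (0.11 log units; within the scatter), and clearly apart from the other, at a 4.6-fold higher number from compound 2 to compound 3 (0.66 log units; beyond the scatter).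

Compound 4 (`Nc1ccccc1CNc1nc(NC2CCC(N)CC2)nc2c1ncn2C1CCCC1`) is not yet measured. Its difference from compound 3 is 2-aminophenyl in place of 5-chloro-2-hydroxyphenyl on a saturated chain carbon bound to a nitrogen on an aromatic ring: 2-aminophenyl in place of 5-chloro-2-hydroxyphenyl, on a saturated chain carbon bound to a nitrogen on an aromatic ring.

Going by the values given here, no measured step covers this exchange directly, but all three steps fall at the same place. The largest are modest, namely a 3.5-fold lower number from compound 1 to compound 2 (0.55 log units; beyond the scatter) and the step to compound 3 already noted. Both the leaving and the entering group hold one six-membered aromatic ring of carbon only, so a smaller change is expected here than those modest steps. In this assay no step beyond the scatter is expected, and the data do not settle a direction. The expected step is a 1.2-fold higher number from compound 3 to compound 4 (0.06 log units; within the scatter). For compound 4 the estimated value is 800 nM, with an expected range of 250 nM to 2500 nM.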

Compound 4, half-maximal inhibitory concentration: 4040 nM
The estimate for compound 4 lay 5.1-fold (0.70 log units) below the measured number; measured number outside the range, above it.
By their numbers in this assay, from the lowest: compound 2; then compounds 1 and 3 (each within the scatter of the next); then compound 4.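

In this assay this position proves sensitive even to an exchange that keeps one six-membered aromatic ring of carbon only, with the same counts of hydrogen-bond donors and acceptors and no net charge on either group: 2-aminophenyl in place of 5-chloro-2-hydroxyphenyl gives a 5.9-fold higher number from compound 3 to compound 4 (0.77 log units; beyond the scatter). Compound 4 also widens the range seen on the saturated chain carbon bound to a nitrogen on an aromatic ring, with a 7.6-fold higher number from compound 1 to compound 4 (0.88 log units; beyond the scatter) and the large 27-fold higher number from compound 2 to compound 4 (1.43 log units; beyond the scatter), which makes compound 4 the weakest of the four and leaves compound 2 the strongest. Nothing measured here accounts for the size of this step, and no outside data bear on it.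

The exchange alters two features at once, the chlorine and the hydroxy-to-amine switch, so the compounds shown cannot assign the step to either one; a plain 2-hydroxyphenyl group would separate the two. Also open, on these data alone, is whether the amine itself carries the step, a question that a dimethylamino or an acetamido group in its place would address.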